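Working notes: extending the chain of compound 1

The compounds below may be only part of what the source reports. "The series", "measured", "known", "first", "only" and "open" are said of these compounds alone.

- compound 1 `CCCCOc1ccc(C2=C(c3ccc(O)cc3)[C@H]3C[C@H](S(=O)(=O)N(CC)c4ccccc4)[C@@H]2O3)cc1`: 3290 nM
- compound 2 `CCCCCCOc1ccc(C2=C(c3ccc(O)cc3)[C@H]3O[C@@H]2C[C@@H]3S(=O)(=O)N(CC)c2ccccc2)cc1`: 970 nM

In a functional assay on MCF7 cells (Homo sapiens) for antiproliferative activity, read by MTT assay, with a stated time of 72 h (on this read-out lower numbers stand for stronger inhibition and higher numbers for weaker inhibition), compound 1 holds the higher of the two numbers, and compound 2 lies lower by more than the usual scatter. Compound 3 `CCCCCCCCOc1ccc(C2=C(c3ccc(O)cc3)[C@H]3C[C@H](S(=O)(=O)N(CC)c4ccccc4)[C@@H]2O3)cc1` has butyl in place of hydrogen on a saturated chain carbon, four bonds along the chain from an oxygen on an aromatic ring. Among the measured compounds shown here, no step between measured compounds is available, so the expectation rests only on compound 2 at 970 nM against compound 1 at 3290 nM as a rough guide. A moderate fall in this assay is expected, though a number close to that of compound 1 remains possible. The expected change is a 3.7-fold lower number from compound 1 to compound 3 (0.56 log units; beyond the scatter) on this estimate. The estimate for compound 3 is 900 nM (280 nM to 3200 nM).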

Compound 3, half-maximal inhibitory concentration: 5890 nM
For compound 3 the middle estimate is 6.5-fold (0.82 log units) below the measured one, outside the stated range (above it).
By their numbers in this assay, from the lowest: compound 2; then compounds 1 and 3 (each within the scatter of the next).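

In this assay, among the compounds shown here, butyl in place of hydrogen on a saturated chain carbon, four bonds along the chain from an oxygen on an aromatic ring, gives a 1.8-fold higher number from compound 1 to compound 3 (0.25 log units; within the scatter) as the only single-place step readable. The chain of compound 1 can thus carry this butyl with no shift beyond the scatter, and the added length brings no gain here. No evidence on hand accounts for this result.

Going by these compounds, whether a chain ending in an amine or a carboxylic acid would behave the same way at this position remains open. On these data alone, a branched chain of similar length is equally open.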